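Longer Chain on Compound 3: Expected Solubility of Compound 4

The compounds below may be only part of what the source reports. "The series", "measured", "known", "first", "only" and "open" are said of these compounds alone.

Of the compounds shown here, three built on a shared core have been measured in a physicochemical assay for solubility, in phosphate buffer, at pH 7.4; a higher number here means a more soluble compound, a lower number a less soluble compound. Compound 1 `COCCOCCOCCOCCOCCOCCOCCOC(=O)Oc1c(C(C)C)cccc1C(C)C` gives 2730 ug/mL. Compound 2 `COCCOCCOCCOC(=O)Oc1c(C(C)C)cccc1C(C)C` gives 190 ug/mL, while compound 3 `COCCOCCOCCOCCOCCOCCOCC(=O)Oc1c(C(C)C)cccc1C(C)C` gives 2020 ug/mL. Compound 1 and compound 2 differ in a single place: a group of 12 heavy atoms (8 carbon, 4 oxygen; no ring) in place of a hydrogen atom, on a saturated chain carbon bound to an oxygen on a saturated carbon That change alone produced a 14-fold higher number from compound 2 to compound 1 (1.16 log units; beyond the scatter). How the core of compound 3 differs from the core of compound 2 is not broken down here; their values simply show compound 3 well above compound 2, and compound 3 sits within the scatter of compound 1.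

Compound 4 `COCCOCCOCCOCCOCCOCCOCCOCCOCCOCCOCC(=O)Oc1c(C(C)C)cccc1C(C)C` has not yet been measured. It carries the same change relative to compound 3 that compound 1 carries relative to compound 2: a group of 12 heavy atoms (8 carbon, 4 oxygen; no ring) in place of a hydrogen atom, on a saturated chain carbon bound to an oxygen on a saturated carbon Because the earlier instance of this change gave a 14-fold higher number from compound 2 to compound 1 (1.16 log units; beyond the scatter), a rise from compound 3 to compound 4 is expected, estimated at a 3.5-fold higher number from compound 3 to compound 4 (0.54 log units; beyond the scatter), smaller than the earlier step since compound 3 already starts from a high value. Compound 4 is therefore expected to come out near 7000 ug/mL, most likely between 2500 ug/mL and 20000 ug/mL.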

Compound 4, solubility: > 371000 ug/mL
Compound 4: no number, only a limit (the forecaster's own chance of this, stated with the estimate: 20%); at least 53-fold (1.72 log units) between middle value and limit.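

Carried from one core to another, the same change, a group of 12 heavy atoms (8 carbon, 4 oxygen; no ring) in place of a hydrogen atom, went the same way in this assay: it gave a 14-fold higher number from compound 2 to compound 1 (1.16 log units; beyond the scatter), and it also gave an at least 180-fold higher number from compound 3 to compound 4 (2.26 log units; beyond the scatter). On these data alone, compound 4 has no exact number, only a limit of the assay: the limit of > 371000 ug/mL in this assay, at which 1 of the 4 values shown sits. The true size of the step on the core of compound 3 therefore stays unknown, and these two pairs show the direction of the change on these two cores only, not a rule for any other core.

The compounds shown leave open whether a still longer chain, or a chain carrying an amine or a carboxylic acid, would move the number in this assay in the same direction. They also leave open whether a third core would follow the same direction, and by how much.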